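Aryl methyl-for-fluoro swap on the acyl azetidine series

This account rests on a few compounds, and the source may have more. Where it says the series, first, only, none or still open, it means among the compounds named here.

Measured so far:
compound 1, `O=C(C1CCC(F)(F)CC1)N1CC(c2nc(-c3cccc(F)c3)no2)C1`, 520 nM
compound 2, `CC1CCCCC1C(=O)N1CC(c2nc(-c3cccc(F)c3)no2)C1`, 540 nM
compound 3, `O=C(c1ccc(F)c(F)c1)N1CC(c2nc(-c3cccc(F)c3)no2)C1`, 3200 nM

All three share a core and differ only in the group on the carbonyl carbon; in an assay on HEK293 cells for positive allosteric modulation of metabotropic glutamate receptor 5 (Homo sapiens), read by FLIPR (a lower number here means that less compound is needed, a higher number that more compound is needed for the effect), compound 1 gives the lowest of the three numbers. Compound 2 sits within the scatter of it, a 1.0-fold higher number from compound 1 to compound 2 (0.02 log units; within the scatter), while compound 3 lies beyond it, a 6.2-fold higher number from compound 1 to compound 3 (0.79 log units; beyond the scatter) and a 5.9-fold higher number from compound 2 to compound 3 (0.77 log units; beyond the scatter).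

Compound 4, `Cc1cccc(-c2noc(C3CN(C(=O)C4CCC(F)(F)CC4)C3)n2)c1`, keeps the group on the carbonyl carbon of compound 1 and alters the aryl ring instead: methyl in place of fluoro on an aromatic carbon. Among the measured compounds shown here, none of the measured steps touches that ring; every one of them changes the group on the carbonyl carbon, so no measured pair bears directly on this change. With nothing in the series pointing either way, the expectation for this assay is a step not beyond the scatter, a 1.2-fold higher number from compound 1 to compound 4 (0.06 log units; within the scatter). Compound 4 is therefore estimated at 600 nM, within 250 nM to 1500 nM.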

Compound 4, half-maximal effective concentration: 590 nM
The estimate for compound 4 lay 1.0-fold (0.01 log units) above the measured number; the measured number falls inside the stated range.
By their numbers in this assay, from the lowest: compounds 1, 2 and 4 (each within the scatter of the next); then compound 3.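

Among the compounds shown here, the earlier compounds varied only the group on the carbonyl carbon, so this is the first reading on the aryl ring. In this assay, with the 4,4-difluorocyclohexyl group held constant, going from 3-fluorophenyl to 3-methylphenyl gives a 1.1-fold higher number from compound 1 to compound 4 (0.05 log units; within the scatter), so at this position the number does not depend on fluoro rather than methyl. Nothing available explains why the two groups read alike.

Still open, on these data alone, is whether the same swap stays within the scatter with other groups on the carbonyl carbon, such as the 3,4-difluorophenyl group of compound 3, whose number is already higher. Also open, as far as these compounds go, is how this aromatic carbon responds to groups of a different kind, such as an amine, a carboxylic acid or a longer alkyl chain.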